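The source may report more compounds than this note shows. Statements on the series, on what has been measured and on what is new or still open speak of the compounds shown alone.

Measured compounds in an assay on HEK293 cells for displacement of a labelled ligand from NPC1-like intracellular cholesterol transporter 1 (Homo sapiens); a higher number here means a weaker inhibitor, a lower number a stronger inhibitor:

Compound 1 `CC(C)(C)c1ccc(C(=O)N2CCC3(CC2)C(=O)N(CC(=O)N2CCN(S(C)(=O)=O)CC2)CN3c2ccccc2)cc1` gives 19000 nM.
Compound 2 `NC(=O)C1CCCN(C(=O)CN2CN(c3ccccc3)C3(CCN(C(=O)c4ccc(C5CCCCC5)cc4)CC3)C2=O)C1` gives 3100 nM.
Compound 3 `CS(=O)(=O)N1CCN(C(=O)CN2CN(c3ccccc3)C3(CCN(C(=O)c4ccc(C5CCCCC5)cc4)CC3)C2=O)CC1` gives 6300 nM.

Compound 1 has the highest number of the three; the nearest is compound 3, with a 3.0-fold lower number from compound 1 to compound 3 (0.48 log units; beyond the scatter), and compound 2 lies further off still. Compound 4 `CC(C)(C)c1ccc(C(=O)N2CCC3(CC2)C(=O)N(CC(=O)NCCCCNS(C)(=O)=O)CN3c2ccccc2)cc1` keeps the tert-butyl group and the shared core of compound 1 and differs only at the amide end: (4-(methanesulfonamido)butyl)amino in place of 4-(methylsulfonyl)piperazin-1-yl on a carbonyl carbon.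

Among the compounds with values here, no measured step changes this position in the same way. The closest comparison is a 2.0-fold higher number from compound 2 to compound 3 (0.31 log units; beyond the scatter), a modest step where one amide substituent is swapped for another while both groups keep a ring. Within the data shown here, the change to compound 4 opens the ring, yet the count of heavy atoms and acceptors stays the same and two donors enter, for which this assay offers no precedent. The expectation is therefore a step no larger than modest, with no clear direction: no change at the digits printed from compound 1 to compound 4 (within the scatter). Compound 4 is estimated at 19000 nM, between 6000 nM and 60000 nM.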

Compound 4, half-maximal inhibitory concentration: 4500 nM
Compound 4: middle estimate off by 4.2-fold (0.63 log units), on the high side; the whole stated range lies above it.
By their numbers in this assay, from the lowest: compounds 2, 4 and 3 (each within the scatter of the next, the first and the last beyond it); then compound 1.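

In this assay, this position on the carbonyl carbon does not depend on a ring: (4-(methanesulfonamido)butyl)amino in place of 4-(methylsulfonyl)piperazin-1-yl gives a 4.2-fold lower number from compound 1 to compound 4 (0.63 log units; beyond the scatter). The earlier step at this position exchanged one ring-bearing group for another, whereas this one shows that an open chain with the same heavy-atom count and 2 hydrogen-bond donors is accepted with the tert-butyl group kept, and the number falls rather than rises. No supporting data bear on why the number moves in this direction.

Open, as far as these compounds go, is whether the step carries over to the cyclohexyl series of compound 3, and whether opening the ring or the added donors accounts for it. Also open, from the compounds shown here alone, is how a shorter or longer chain, or an amine or a carboxylic acid in place of the methanesulfonamido group, would read here.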